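Sulfanyl in place of benzylamino on the deoxy series

This account rests on a few compounds, and the source may have more. Where it says the series, first, only, none or still open, it means among the compounds named here.

Three compounds of the series carry numbers in a functional assay (Homo sapiens) for inhibition of Nucleic Acid, tested at 100 uM (on this read-out higher numbers stand for more inhibition at the one concentration tested (going by the name of the read-out) and lower numbers for less inhibition), so far. Compound 1 `OC[C@H]1O[C@@H](n2cnc3c(NCc4ccccc4)nccc32)C[C@@H]1O` gives 15% in this assay. Compound 2 `c1ccc(CNc2[nH]ccc3ncnc2-3)cc1`, which lacks the sugar, gives 75%. Compound 3 `OC[C@H]1OC(n2cnc3c(Nc4ccccc4)nccc32)[C@H](O)[C@@H]1O`, with an anilino group and the fully hydroxylated sugar, gives 4%. Compound 1 thus stands second of the three: its number lies above that of compound 3 by a margin beyond the scatter, and far below that of compound 2, again beyond the scatter. No two of these compounds differ in a single place, so no single step can be read from the measured set.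

Compound 4 `OC[C@H]1O[C@@H](n2cnc3c(S)nccc32)C[C@@H]1O` is the next compound to be measured. Relative to compound 1 the change is sulfanyl in place of benzylamino on an aromatic carbon.

Among the measured compounds shown here, the benzylamino group is shared by compound 1 and compound 2, the only two compounds with a number above that of compound 3; removing it is expected to cost some inhibition rather than gain it, but compound 1 already sits low, so the step is expected to be small, at most around the edge of the scatter and downward. For compound 4 the estimate is 8%, with a range from 0% to 25%, which corresponds to an expected step of a number 7 percentage points lower from compound 1 to compound 4 (within the scatter).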

Compound 4, a percentage reported as inhibition, at one concentration (the size of the read-out at that concentration, not a potency): 10%
Compound 4: middle estimate off by 2 percentage points, on the low side; the range from low to high includes it.
By their numbers in this assay, from the lowest: compounds 3, 4 and 1 (each within the scatter of the next, the first and the last beyond it); then compound 2.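

Going from benzylamino to sulfanyl on this aromatic carbon gives a number 5 percentage points lower from compound 1 to compound 4 (within the scatter) in this assay. Among the compounds shown here, this is the first pair that differs in one place, and it shows that, with the deoxy sugar of compound 1 kept, this position next to the ring nitrogen can lose the benzylamino group, with its six-membered aromatic ring of carbon only, and take a single sulfur atom without a step beyond the scatter. No measurement at hand accounts for this outcome.

From the compounds shown here alone, both members of the pair sit low on this read-out, so it remains unknown whether a plain amino group, a methylsulfanyl group or a chlorine atom on the same carbon would read any differently. Also open, going by these compounds, is whether the sulfanyl change would give a similar step without the sugar, in the setting of compound 2 at 75%, and whether it would do so on the fully hydroxylated sugar of compound 3 at 4%.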